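Swapping the Amide Aryl Group on a Shared Core

This account rests on a few compounds, and the source may have more. Where it says the series, first, only, none or still open, it means among the compounds named here.

Compound 2 `CS(=O)(=O)c1ccc(C(=O)Nc2ccc(Cl)c(-c3nnc4c(Cl)cccn34)c2)cc1` and compound 1 `Cc1nc(C(=O)Nc2ccc(Cl)c(-c3nnc4c(Cl)cccn34)c2)cs1` share one core and differ only in the group on the carbonyl carbon. In a functional assay on MDA-MB-231 cells (Homo sapiens) for antiproliferative activity, read by MTT assay, with stated times of 72 h and 4 h (a lower number here means a stronger inhibitor, a higher number a weaker inhibitor), compound 1 gives only the assay limit > 100000 nM. In this assay compound 2 likewise gives only the limit > 100000 nM. The step that the two limits leave unreadable from compound 1 to compound 2 is therefore not readable, since the limit of > 100000 nM in this assay, at which 2 of the 2 values shown sit, holds both values. Compound 3 `O=C(Nc1ccc(Cl)c(-c2nnc3c(Cl)cccn23)c1)c1ccc(Cl)cc1Cl` carries 2,4-dichlorophenyl in place of 4-(methylsulfonyl)phenyl on a carbonyl carbon. Going by the values given here, no measured step shows how such a change acts, so nothing beyond the scatter is expected in this assay. Compound 3 is estimated at 100000 nM, between 20000 nM and 400000 nM. The expected step is a number no higher from compound 2 to compound 3 (the limit leaves the size open).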

Compound 3, half-maximal inhibitory concentration: > 100000 nM
Compound 3: only a limit was reported; the forecaster's own chance of this, stated with the estimate: 70%; the middle value sits exactly at the limit.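

No step among compound 1, compound 2 and compound 3 can be read, as all three give only an assay limit: the limit of > 100000 nM in this assay, at which 3 of the 3 values shown sit.

As far as these compounds go, whether swapping the group on the carbonyl carbon changes activity at all in this assay stays open.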